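A few compounds are considered here, and "the series" means these few. Any claim that something is new, unique, unknown or untested is made for them only; others in the source may bear on it.

Measured so far:
Compound 1, `CO/N=c1\[nH]cnc2c1[n+](C/C=C(\C)CC/C=C(\C)CC/C=C(\C)CCC=C(C)C)cn2Cc1ccccc1`, gives 1040 nM in a functional assay on cells (Homo sapiens) for cytotoxicity; a lower number here means a stronger inhibitor, a higher number a weaker inhibitor.
Compound 2, `CO/N=c1\[nH]cnc2c1[n+](C/C=C(\C)CC/C=C(\C)CC/C=C(\C)CCC=C(C)C)cn2C(c1ccccc1)c1ccccc1`, gives 2600 nM in this assay.

Among the compounds with values here, of these two numbers, compound 2 has the higher one, meaning the weaker inhibitor; the single comparison available, the step of a 2.5-fold higher number from compound 1 to compound 2 (0.40 log units; beyond the scatter), lies beyond the scatter. Compound 3, `CC(C)=CCC/C(C)=C/CC/C(C)=C/CC/C(C)=C/C[n+]1cn(C(c2ccccc2)c2ccccc2)c2nc[nH]/c(=N\OCc3ccccc3)c21`, has not been tested. It differs from compound 2 in one place: phenyl in place of hydrogen on a saturated chain carbon bound to an oxygen, so the methoxy of compound 2 becomes a benzyloxy. Within the data shown here, the only measured step that speaks to this, a 2.5-fold higher number from compound 1 to compound 2 (0.40 log units; beyond the scatter), also put a phenyl in place of a hydrogen, though on the carbon bound to an aromatic carbon and an aromatic nitrogen rather than on the carbon bound to an oxygen, and it weakened inhibition modestly. Nothing measured shows what a phenyl at the oxygen-bound carbon does, so the expectation is uncertain. A small weakening, or a change within the scatter, is expected in this assay for compound 3, estimated as a 1.5-fold higher number from compound 2 to compound 3 (0.19 log units; within the scatter). Compound 3 is expected to give about 4000 nM, within a range from 1500 nM to 11000 nM.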

Compound 3, half-maximal inhibitory concentration: 59000 nM
Compound 3: middle estimate off by 15-fold (1.17 log units), on the low side; measured number above the stated range.
By their numbers in this assay, from the lowest: compound 1; then compound 2; then compound 3.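

The change from methoxy to benzyloxy gives a 23-fold higher number from compound 2 to compound 3 (1.36 log units; beyond the scatter) in this assay and is the largest change among these compounds. It shows that a phenyl in place of hydrogen on the saturated chain carbon bound to an oxygen can cost far more than the earlier phenyl change on the carbon bound to an aromatic carbon and an aromatic nitrogen, which gave only a 2.5-fold higher number from compound 1 to compound 2 (0.40 log units; beyond the scatter) in the same assay. The effect of adding a phenyl therefore depends strongly on where it is added, but no available information explains why this one weakens inhibition so much.

This single step leaves open whether the same change from methoxy to benzyloxy would weaken compound 1 as strongly as it weakened compound 2, which already carries one more phenyl than compound 1. It also leaves open whether the loss follows from the size of the new group or from the phenyl ring itself, a question that an ethoxy group, a longer saturated chain or a cyclohexylmethoxy group on the same oxygen could help to answer.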